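A few compounds are considered here, and "the series" means these few. Any claim that something is new, unique, unknown or untested is made for them only; others in the source may bear on it.

In a functional assay on MDA-MB-231 cells (Homo sapiens), read by microscopy and transwell migration, with a stated time of 24 h (on this read-out higher numbers stand for weaker inhibition and lower numbers for stronger inhibition), compound 1 `COc1ccc(C(=O)Nc2nc(-c3cc(OC)c(OC)c(OC)c3)cs2)cc1` gives > 25000 nM, which is a limit of the assay and not a number. For the measured compounds named here, compound 2 `COc1ccc(C(=O)/N=c2\scc(-c3cc(OC)c(OC)c(OC)c3)n2C)cc1` gives 8040 nM, the only true number so far in this assay. Compound 3 `COc1cccc(C(=O)/N=c2\scc(-c3cc(OC)c(OC)c(OC)c3)n2C)c1` has the same atoms joined differently, with 3-methoxyphenyl in place of 4-methoxyphenyl on a carbonyl carbon. Going by the values given here, no measured pair shows what such a swap does, so the starting point is compound 2 at 8040 nM, and no change beyond the scatter is expected. The expected step is a 1.1-fold higher number from compound 2 to compound 3 (0.05 log units; within the scatter). For compound 3, the estimate is 9000 nM, with an expected range of 3000 nM to 25000 nM.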

Compound 3, half-maximal inhibitory concentration: > 50000 nM
Compound 3: only a limit was reported; the forecaster's own chance of this, stated with the estimate: 20%; middle value at least 5.5-fold (0.74 log units) away from the limit.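

In this assay, 3-methoxyphenyl in place of 4-methoxyphenyl on a carbonyl carbon gives an at least 6.2-fold higher number from compound 2 to compound 3 (0.79 log units; beyond the scatter). This shows that activity here depends on how the same atoms are joined, and not only on which atoms are present. Compound 3 stands at a limit of the assay and not at a number, so the step has no known upper end: the limit of > 50000 nM in this assay, at which 1 of the 3 values shown sits.

The compounds shown leave open how other groups at this place would behave, such as a phenyl ring carrying an amine or a carboxylic acid instead of methoxy. Going by these compounds, whether any such group could give a lower number than compound 2 at 8040 nM also remains open.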